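The source may hold more compounds than are shown below. What is called first, only, known or untested is meant among the compounds shown, and "the series" means these compounds.

Measured in an ADME assay on HFF cells (Homo sapiens) for cytotoxicity, with a stated time of 8 days; a lower number here means that less compound is tolerated, a higher number that more compound is tolerated:
- Compound 1 `CCCNc1nc(N)nc2c1ncn2/C=C1/CC1(CO)CO`: > 300000 nM
- Compound 2 `Nc1nc(NC2CCCC2)c2ncn(/C=C3/CC3(CO)CO)c2n1`: > 300000 nM

Neither entry is a number. Compound 2 has only a limit, > 300000 nM, and no exact value. The shared position is the limit of > 300000 nM in this assay, at which 2 of the 2 values shown sit.

Compound 3 `CCCCCCCCSc1nc(N)nc2c1ncn2/C=C1/CC1(CO)CO` carries octylsulfanyl in place of cyclopentylamino on an aromatic carbon.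

Among the measured compounds shown here, only one measured step bears on this change, a step that the two limits leave unreadable from compound 1 to compound 2. For the measured compounds named here, it gives no size to carry forward, and it replaces one group on a nitrogen with another, so no measured compound shows what octylsulfanyl does. Any forecast is therefore tentative. A moderate move towards less compound being tolerated is expected, though compound 3 may also stay at the limit.

The estimated change is an at least 3.0-fold lower number from compound 2 to compound 3 (0.47 log units; beyond the scatter). For compound 3 the expected value is 100000 nM, with an estimated range of 25000 nM to 300000 nM.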

Compound 3, half-maximal cytotoxic concentration: > 300000 nM
Compound 3: a limit, no number; the forecaster's own chance of this, stated with the estimate: 40%; middle value at least 3.0-fold (0.47 log units) from the limit.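

The result for compound 3 in this assay is again a limit, not a number, so its steps from compound 1 and compound 2 cannot be read: the limit of > 300000 nM in this assay, at which 3 of the 3 values shown sit.

The compounds shown leave open whether propylamino, cyclopentylamino and octylsulfanyl differ at all in tolerated concentration.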